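Working notes: chloro exchanged for trifluoromethyl in one series

The source may report more compounds than this note shows. Statements on the series, on what has been measured and on what is new or still open speak of the compounds shown alone.

Compound 1 `O/N=C(/Nc1cccc(C(F)(F)F)c1)c1ccc2occc2c1` and compound 2 `O/N=C(/Nc1ccc(F)c(Cl)c1)c1ccc2occc2c1` share one core and differ only in the groups on the six-membered aromatic ring of carbon only. In an assay on tissue (HeLa cells) for inhibition of Indoleamine 2,3-dioxygenase 1 (Homo sapiens), read by spectrophotometry (a lower number here means a stronger inhibitor, a higher number a weaker inhibitor), compound 1 gives 1900 nM and compound 2 gives 1800 nM. Compound 2 holds the lowest of the two numbers, yet the gap to compound 1 lies within the scatter, so the two cannot be told apart.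

Compound 3 `O/N=C(/Nc1ccc(F)c(C(F)(F)F)c1)c1ccc2occc2c1` is not yet measured. It differs from compound 2 by trifluoromethyl in place of chloro on an aromatic carbon. For the measured compounds named here, no measured pair isolates this exchange. The expected step in this assay is no change at the digits printed from compound 2 to compound 3 (within the scatter), no more than the scatter, because compound 1 carries the same trifluoromethyl group and gives 1900 nM. Compound 3 is therefore expected near 1800 nM in this assay, with a range from 900 nM to 3600 nM.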

Compound 3, half-maximal inhibitory concentration: 2200 nM
Estimate against measurement, compound 3: 1.2-fold (0.09 log units) below, and the stated range covers the measured number.
By their numbers in this assay, from the lowest: compounds 2, 1 and 3 (each within the scatter of the next).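

In this assay, for the compounds shown here, trifluoromethyl in place of chloro, ortho to a fluoro group, gives a 1.2-fold higher number from compound 2 to compound 3 (0.09 log units; within the scatter), the first direct reading of this exchange at this position, and the two groups cannot be told apart here. Fluoro in place of hydrogen on the trifluoromethyl-bearing ring gives a 1.2-fold higher number from compound 1 to compound 3 (0.06 log units; within the scatter), so that addition cannot be told apart from the scatter either. No evidence on the cause of either result is available.

The compounds shown leave open how an amine, a carboxylic acid or a methoxy group would read at this position, since chloro and trifluoromethyl alone occupy it in the fluoro-bearing pair. Going by these compounds alone, also open is whether fluoro in place of hydrogen would read the same alongside chloro, as no pair isolates that exchange.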